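The source may report more compounds than this note shows. Statements on the series, on what has been measured and on what is new or still open speak of the compounds shown alone.

Compound 3 `COc1cc(-c2nn(-c3cccc(NC(=O)Nc4cccc(C(F)(F)F)c4)c3)cc2-c2ccncc2)ccc1Cl` gives 3410 nM in a functional assay on NCI-H23 cells (Homo sapiens) for inhibition, read by sulforhodamine B assay, with a stated time of 48 h; on this read-out higher numbers stand for weaker inhibition of growth and lower numbers for stronger inhibition of growth; of the two numbers shown, the other, compound 2 `COc1cc(-c2nn(-c3cccc(NC(=O)Nc4cc(C(F)(F)F)cc(C(F)(F)F)c4)c3)cc2-c2ccncc2)ccc1Cl` with 3340 nM, sits within the scatter of it. Among the measured compounds shown here, compound 1 `O=C(Nc1cccc(-n2cc(-c3ccncc3)c(-c3ccc(Cl)c(O)c3)n2)c1)Nc1cccc(C(F)(F)F)c1` gives > 32500 nM, a limit of the assay and not a number; it is the single value at the limit of > 32500 nM in this assay, at which 1 of the 3 values shown sits. Compound 4 `COc1cc(-c2nn(-c3cccc(NC(=O)Nc4ccc(Cl)c(C(F)(F)F)c4)c3)cc2-c2ccncc2)ccc1Cl` differs from compound 3 by chloro in place of hydrogen on an aromatic carbon. Two measured steps exist: an at least 9.5-fold lower number from compound 1 to compound 3 (0.97 log units; beyond the scatter) and a 1.0-fold higher number from compound 2 to compound 3 (0.01 log units; within the scatter). The second of these lies on the same ring as the change to compound 4 and stayed within the scatter; the first sits on a different ring. A step within the scatter, if anything slightly lower, is therefore expected in this assay. Compound 4 is estimated at 2600 nM, between 900 nM and 8000 nM. That expectation corresponds to a 1.3-fold lower number from compound 3 to compound 4 (0.12 log units; within the scatter).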

Compound 4, concentration for total growth inhibition: 8030 nM
Compound 4: the middle estimate sits 3.1-fold (0.49 log units) below what was measured; measured number outside the range, above it.
By their numbers in this assay, from the lowest: compounds 2 and 3 (each within the scatter of the next); then compound 4. At a limit, above all of these: compound 1.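

On the ring carrying the trifluoromethyl group, chloro at the position para to a large group gives a 2.4-fold higher number from compound 3 to compound 4 (0.37 log units; beyond the scatter) in this assay and thus weaker inhibition of growth. Among the compounds shown here, this is the first change on this ring to go beyond the scatter, whereas the step of a 1.0-fold higher number from compound 2 to compound 3 (0.01 log units; within the scatter) stayed within it, so the ring does not tolerate every substitution equally. Nothing shown bears on the cause of this step.

Going by these compounds, whether the weakening is specific to chloro remains open, as a single substituent at this position cannot settle it. An amine or a carboxylic acid there would test how far it extends.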